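From propyl to propargyl on a shared core

A few compounds are considered here, and "the series" means these few. Any claim that something is new, unique, unknown or untested is made for them only; others in the source may bear on it.

Compound 1 `CCn1c(-c2ccccc2)cs/c1=N\C(=O)c1ccccc1` gives 51.5 nM
Compound 2 `CCCn1c(-c2ccccc2)cs/c1=N\C(=O)c1ccccc1` gives 657 nM

Both values come from a functional assay on MDA-MB-231 cells (Homo sapiens), read by microscopy and transwell migration, with a stated time of 24 h (a lower number here means a stronger inhibitor, a higher number a weaker inhibitor), and, of the two, compound 2 holds the higher number and so is the weaker inhibitor. Compound 3 `C#CCn1c(-c2ccccc2)cs/c1=N\C(=O)c1ccccc1` has not yet been measured. It differs from compound 2 by one change (ethynyl in place of ethyl on a saturated chain carbon bound to an aromatic nitrogen), which can also be read as propyl to propargyl. For the measured compounds named here, only one measured step bears on this change (a 13-fold higher number from compound 1 to compound 2 (1.11 log units; beyond the scatter)). That step is large and beyond the scatter, and it shows that a small change in this chain can move the number a long way. However, neither measured compound carries a triple bond, so the data cannot fix the direction firmly. A moderate move back towards compound 1 seems most likely, smaller than the measured step, with a wide margin of doubt. The expected change is a lower number (a 2.6-fold lower number from compound 2 to compound 3 (0.42 log units; beyond the scatter)), and this remains an estimate. For compound 3 the estimated value is 250 nM with an expected range from 50 nM to 1200 nM in this assay as well.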

Compound 3, half-maximal inhibitory concentration: 2780 nM
Estimate against measurement, compound 3: 11-fold (1.05 log units) below; measured number outside the range, above it.
By their numbers in this assay, from the lowest: compound 1; then compound 2; then compound 3.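

Replacing the ethyl end of the propyl chain with ethynyl, on a saturated chain carbon bound to an aromatic nitrogen, does not recover the strength lost on going from compound 1 to compound 2: in this assay this change gives a 4.2-fold higher number from compound 2 to compound 3 (0.63 log units; beyond the scatter) and so a weaker inhibitor. Ethyl and ethynyl each count 2 heavy atoms, so the number at this position depends on more than the count of atoms in the chain, and a triple bond is enough to shift it. The full span is a 54-fold higher number from compound 1 to compound 3 (1.73 log units; beyond the scatter) and compound 1 remains the strongest inhibitor of the three, its steps to both others lying beyond the scatter, but nothing available here explains why the triple bond has this effect.

These three compounds leave open how a double bond would compare, as in an allyl chain, and whether a butyl chain would raise the number further. From the compounds shown here alone, it also remains open whether a chain ending in an amine or a carboxylic acid would be tolerated at this position, and whether the same order would hold on a different core.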